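The source may hold more compounds than are shown below. What is called first, only, known or untested is meant among the compounds shown, and "the series" means these compounds.

In a functional assay on the whole organism (strain Sprague-Dawley) for inhibition, with Rattus norvegicus as the target, with a stated time of 10 min (a higher number here means that more compound is needed for the effect, a lower number that less compound is needed), compound 1 (`O=C(O)c1cnc(-c2ccccc2)[nH]c1=O`) stands at 50 mg/kg and compound 2 (`O=C(O)c1cnc(-c2ccccc2F)[nH]c1=O`) at 5 mg/kg while compound 3 (`CC(C)Oc1ccccc1-c1ncc(C(=O)O)c(=O)[nH]1`) holds the lowest of the three numbers at 0.8 mg/kg in this series. The unmeasured compound 4 (`CCC(C)Oc1ccccc1-c1ncc(C(=O)O)c(=O)[nH]1`) differs from compound 3 by methyl in place of hydrogen on a saturated chain carbon, two bonds along the chain from an oxygen on an aromatic ring, which turns isopropoxy into sec-butoxy (methyl in place of hydrogen on a saturated chain carbon, two bonds along the chain from an oxygen on an aromatic ring). Each measured step changes a group on an aromatic carbon: a 10-fold lower number from compound 1 to compound 2 (1.00 log units; beyond the scatter) and a 63-fold lower number from compound 1 to compound 3 (1.80 log units; beyond the scatter) and finally a 6.3-fold lower number from compound 2 to compound 3 (0.80 log units; beyond the scatter) with all three beyond the scatter. Among the measured compounds shown here, no step on the chain itself has been measured, so these steps offer only indirect guidance. In this assay no change beyond the scatter is expected, and no direction is clearly favoured (expected step: a 1.1-fold lower number from compound 3 to compound 4 (0.06 log units; within the scatter)). The estimate for compound 4 is 0.7 mg/kg (estimated range: 0.25 mg/kg to 2.5 mg/kg).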

Compound 4, dose for 50% inhibition: 0.5 mg/kg
Beside the measured number, compound 4's estimate is 1.4-fold (0.15 log units) above it; low and high end bracket the measured number.
By their numbers in this assay, from the lowest: compounds 4 and 3 (each within the scatter of the next); then compound 2; then compound 1.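

In this assay, the change on the saturated chain carbon itself gives a 1.6-fold lower number from compound 3 to compound 4 (0.20 log units; within the scatter), so methyl in place of hydrogen at this position, which turns isopropoxy into sec-butoxy, separates neither compound from the other. The advantage over the fluoro and unsubstituted compounds persists with sec-butoxy, as a 10-fold lower number from compound 2 to compound 4 (1.00 log units; beyond the scatter) and a 100-fold lower number from compound 1 to compound 4 (2.00 log units; beyond the scatter) show. Nothing at hand accounts for these results. Open, going by these compounds, is whether a longer chain on the oxygen, such as hexyloxy, or an amine at the chain end would remain within the scatter of compound 3.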